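The source may hold more compounds than are shown below. What is called first, only, known or untested is meant among the compounds shown, and "the series" means these compounds.

Measured in a functional assay on HT-29 cells (Homo sapiens) for cytotoxicity, read by MTT assay, with a stated time of 72 h (a higher number here means a weaker inhibitor, a lower number a stronger inhibitor), where every value is a limit of the assay and not a number:
Compound 1 `Nc1ccc(Nc2c(C(=O)NCc3ccc(F)cc3)nc(Br)c3cccnc23)cc1` gives > 10000 nM
Compound 2 `O=C(NCCCNc1c(C(=O)NCc2ccc(F)cc2)nc(Br)c2cccnc12)c1ccccc1` gives > 10000 nM
Compound 3 `COC(=O)CNc1c(C(=O)NCc2ccc(F)cc2)nc(Br)c2cccnc12` gives > 10000 nM

Compound 3 stands at the limit of > 10000 nM in this assay, at which 3 of the 3 values shown sit. Compound 4 `NCCCCCCNc1c(C(=O)NCc2ccc(F)cc2)nc(Br)c2cccnc12` carries 5-aminopentyl in place of methoxycarbonyl on a saturated chain carbon bound to a nitrogen on an aromatic ring. Among the compounds with values here, two measured steps bear on this change: a step that the two limits leave unreadable from compound 1 to compound 3 and a step that the two limits leave unreadable from compound 2 to compound 3. Neither has a readable size, so neither sets a direction for this assay. The expected step is a number no higher from compound 3 to compound 4 (the limit leaves the size open), and it is only loosely estimated. Compound 4 is expected to give 10000 nM, with an estimated range from 3000 nM to 30000 nM.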

Compound 4, half-maximal inhibitory concentration: 5000 nM
Compound 4: the middle estimate sits 2.0-fold (0.30 log units) above what was measured; the measured number falls inside the stated range.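

Within the data shown here, compound 4 is the only compound here that gives a readable number in this assay, and it carries 6-aminohexyl on a nitrogen on an aromatic ring. The change from the other groups at this place gives an at least 2.0-fold lower number from compound 3 to compound 4 (0.30 log units; that floor lies within the scatter), an at least 2.0-fold lower number from compound 2 to compound 4 (0.30 log units; that floor lies within the scatter) and an at least 2.0-fold lower number from compound 1 to compound 4 (0.30 log units; that floor lies within the scatter). The other values are limits, not numbers: the limit of > 10000 nM in this assay, at which 3 of the 4 values shown sit.

From the compounds shown here alone, the true size of each step stays open. Also open, going by these compounds, is whether a longer chain, or a carboxylic acid in place of the amine of 6-aminohexyl, would keep a readable number.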